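The compounds below may be only part of what the source reports. "The series", "measured", "known", "first", "only" and "open" are said of these compounds alone.

In a functional assay on DU-145 cells (Homo sapiens) for cytotoxicity, read by sulforhodamine B assay (on this read-out higher numbers stand for weaker inhibition of growth and lower numbers for stronger inhibition of growth), compound 2 (`Cc1ccc2c(c1)CCCN2c1nc(C)nc2ccccc12`) at 187 nM stands highest of the two measured numbers, with compound 1 (`Cc1ccc2c(c1)CCCN2c1nc(Cl)nc2ccccc12`) at 57 nM. Compound 3 (`Cc1nc(N2CCCc3cc(Br)ccc32)c2ccccc2n1`) differs from compound 2 by bromo in place of methyl on an aromatic carbon. Among the compounds with values here, the only measured step, a 3.3-fold higher number from compound 1 to compound 2 (0.52 log units; beyond the scatter), is a methyl in place of chloro, but not at this place, so it bears only indirectly. Read in reverse, it suggests a modest move to a lower number at most. The expected step is a 1.6-fold lower number from compound 2 to compound 3 (0.19 log units; within the scatter). For compound 3 the estimate is 120 nM, with an expected range of 40 nM to 350 nM.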

Compound 3, concentration for 50% growth inhibition: 198 nM
For compound 3 the middle estimate is 1.7-fold (0.22 log units) below the measured one, and the stated range covers the measured number.
By their numbers in this assay, from the lowest: compound 1; then compounds 2 and 3 (each within the scatter of the next).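

In this assay, bromo in place of methyl on this aromatic carbon gives a 1.1-fold higher number from compound 2 to compound 3 (0.02 log units; within the scatter), so the two groups read alike at this position. Within the data shown here, the only step beyond the scatter so far, a 3.3-fold higher number from compound 1 to compound 2 (0.52 log units; beyond the scatter), lies at another place on the core. No evidence on either group bears on this result. Open, going by these compounds, is whether an amine or a carboxylic acid at this aromatic carbon would read as these two groups do. Also open, on these data alone, is whether bromo here reads the same when chloro replaces the methyl at that other place.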